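Tertiary amine series: cytotoxicity working notes

The compounds below may be only part of what the source reports. "The series", "measured", "known", "first", "only" and "open" are said of these compounds alone.

Measured so far:
compound 1 `Cc1ccc2cc(CN(Cc3ccc(C(C)(C)C)cc3)C3CCCC3)c(=O)[nH]c2c1` — > 10000 nM
compound 2 `CCc1ccc2cc(CN(Cc3ccc(C(C)(C)C)cc3)C3CCCC3)c(=O)[nH]c2c1` — > 9000 nM
compound 3 `COc1ccc(CN(Cc2ccc(C(C)(C)C)cc2)Cc2cc3ccccc3[nH]c2=O)cc1` — 1800 nM

In a toxicity assay on MDCK cells (Canis lupus familiaris) for cytotoxicity, read by crystal violet staining, with a stated time of 48 h (a lower number here means that less compound is tolerated, a higher number that more compound is tolerated), compound 1 gives > 10000 nM. That value is a limit of the assay, not a number. Compound 2 gives > 9000 nM in this assay. That value too is a limit, not a number. Among the compounds with values here, compound 3 gives 1800 nM in this assay, the only number among the three values shown.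

Compound 1 and compound 2 differ by methyl in place of hydrogen on a saturated chain carbon bound to an aromatic carbon. The step between them, a step that the two limits leave unreadable from compound 1 to compound 2, cannot be read because the limit of > 10000 nM in this assay, at which 1 of the 3 values shown sits, and the limit of > 9000 nM in this assay, at which 1 of the 3 values shown sits, are the two values it joins. How the core of compound 3 differs from the core of compound 1 is not broken down here.

Compound 4 `COc1ccc([C@H](C)N(Cc2ccc(C(C)(C)C)cc2)Cc2cc3ccccc3[nH]c2=O)cc1` has not yet been measured. It differs from compound 3 by methyl in place of hydrogen on a saturated chain carbon bound to an amine nitrogen and an aromatic carbon. Within the data shown here, this is the same kind of change as the one from compound 1 to compound 2, not the same change: there the place is a saturated chain carbon bound to an aromatic carbon, here a saturated chain carbon bound to an amine nitrogen and an aromatic carbon. In this assay the expected step is a 1.1-fold higher number from compound 3 to compound 4 (0.05 log units; within the scatter), a step judged to stay within the usual scatter, resting on compound 3 with 1800 nM as the only readable anchor and on the fact that the earlier step of the same kind gives no readable size. Compound 4 is expected to come out at 2000 nM, with the range 800 nM to 5500 nM held wide for that reason.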

Compound 4, half-maximal cytotoxic concentration: 1800 nM
For compound 4 the middle estimate is 1.1-fold (0.05 log units) above the measured one; the measured number falls inside the stated range.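

In this assay, methyl in place of hydrogen on a saturated chain carbon bound to an amine nitrogen and an aromatic carbon gives no change at the digits printed from compound 3 to compound 4 (within the scatter), so on the core of compound 3 the change from 4-methoxybenzyl to 1-(4-methoxyphenyl)ethyl leaves the read-out without a measurable shift. The same kind of change on the core of compound 1 sits at a different place and cannot be read, because compound 1 stands at a limit of the assay, not a number: the limit of > 10000 nM in this assay, at which 1 of the 4 values shown sits. Compound 2 also stands at a limit, so the earlier pair gives no size to set against the new step, and this single readable step does not show whether the change carries from one core to another: the limit of > 9000 nM in this assay, at which 1 of the 4 values shown sits.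

The compounds shown leave open whether a longer chain such as ethyl, or an amine or a carboxylic acid carried on that same chain carbon, would read any differently from the methyl of compound 4. On these data alone, how the mirror-image form of compound 4 would read in this assay also stays open, as does the size of this change on any core that gives a number rather than a limit.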